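The source may hold more compounds than are shown below. What is called first, only, known or untested is meant among the compounds shown, and "the series" means these compounds.

Measured compounds:
- compound 1, `Cc1ccc(Nc2cc(NC(=O)Nc3c(Cl)cccc3Cl)ncn2)cc1C`, 47.5%
- compound 2, `COc1cc(NC(=O)Nc2cc(Nc3cccc(C(C)(C)C)c3)ncn2)cc(OC)c1`, 13.1%
- compound 3, `CC(C)(C)c1ccc(Nc2cc(NC(=O)Nc3c(Cl)cccc3Cl)ncn2)cc1`, 22%

All three were tested in a functional assay on NCI-H520 cells (Homo sapiens) for inhibition, read by MTT assay, with a stated time of 48 h, tested at 10 uM; a lower number here means less inhibition, a higher number more inhibition at the concentration tested (going by the name of the read-out). In this assay compound 2 gives 13.1%, the smallest of the three numbers, but its gap to compound 3, which gives 22%, lies within the usual scatter, so the two cannot be told apart. Compound 1, which gives 47.5%, stands beyond the scatter above compound 2.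

Compound 4, `COc1cc(NC(=O)Nc2cc(Nc3ccc(OC)c(I)c3)ncn2)cc(OC)c1`, has not yet been measured. It differs from compound 2 in one place: 3-iodo-4-methoxyphenyl in place of 3-(tert-butyl)phenyl on a nitrogen on an aromatic ring. Among the measured compounds shown here, no measured pair here shares this same change, so there is no step to lean on. Since the three measured numbers span only a modest range and two of them sit within the scatter of one another, the step from compound 2 to compound 4 in this assay is expected to be small, estimated at a number 6.9 percentage points higher from compound 2 to compound 4 (within the scatter), with no clear direction beyond the scatter. Compound 4 is therefore expected to give about 20% in this assay, most likely between 5% and 40%.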

Compound 4, a percentage reported as inhibition, at one concentration (the size of the read-out at that concentration, not a potency): 46.5%
Compound 4: the middle estimate sits 26.5 percentage points below what was measured; measured number outside the range, above it.
By their numbers in this assay, from the lowest: compounds 2 and 3 (each within the scatter of the next); then compounds 4 and 1 (each within the scatter of the next).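

Putting 3-iodo-4-methoxyphenyl in place of 3-(tert-butyl)phenyl on a nitrogen on an aromatic ring gives a number 33.4 percentage points higher from compound 2 to compound 4 (beyond the scatter) in this assay. Among the compounds shown here, the earlier compounds offered no step between close relatives, so this pair is the first to show that the group at this place can move the read-out while the rest of the molecule stays the same. The entering group differs in more than one way, with an iodine and a methoxy group on its ring, and nothing available here explains the step.

As far as these compounds go, whether the iodine or the methoxy group alone would give a similar step remains open. So does how a phenyl ring carrying an amine or a carboxylic acid would behave on this nitrogen.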